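The compounds below may be only part of what the source reports. "The series", "measured", "known", "first", "only" and "open" are said of these compounds alone.

Of the compounds shown here, two built on a shared core have already been tested in a toxicity assay on HepG2 cells (Homo sapiens) for inhibition, read by resazurin assay, with a stated time of 24 h; on this read-out lower numbers stand for higher toxicity in this test and higher numbers for lower toxicity in this test. Compound 1 `Cn1c([N+](=O)[O-])cnc1C(=O)NC1CC1` gives > 100000 nM in this assay, which is a limit of the assay rather than a number. Compound 2 `Cn1c([N+](=O)[O-])cnc1C(=O)NC1CCCCC1` gives > 100000 nM in this assay, again a limit and not a measured value. Going by the values given here, the single step between them, a step that the two limits leave unreadable from compound 1 to compound 2, cannot be read because both of its ends sit at the limit of > 100000 nM in this assay, at which 2 of the 2 values shown sit. Compound 2 therefore stands at the limit, with no number to place it more closely.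

Compound 3 `O=C(NC1CCCCC1)c1ncc([N+](=O)[O-])[nH]1` differs from compound 2 by hydrogen in place of methyl on an aromatic nitrogen. Among the compounds with values here, no measured step touches the aromatic nitrogen, and the one step that exists is unreadable, so there is nothing on which to base an expected move in this assay in either direction beyond the usual scatter. Compound 3 is expected to sit where compound 2 sits, with an estimated 150000 nM and a range from 60000 nM to 400000 nM, most likely again reported only as a limit. That estimate means an expected step that the limit leaves unreadable from compound 2 to compound 3, nothing beyond the scatter.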

Compound 3, half-maximal cytotoxic concentration: > 100000 nM
Compound 3 was reported as a limit; the forecaster's own chance of this, stated with the estimate: 80%; the middle value lies beyond the limit too.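

In this assay compound 3 gives > 100000 nM, which is a limit and not a number. The step from compound 2 to compound 3 cannot be read, because both of its ends sit at a limit: the limit of > 100000 nM in this assay, at which 3 of the 3 values shown sit.

The compounds shown leave open how far each lies from that limit in this assay, and whether hydrogen in place of methyl on the aromatic nitrogen changes the read-out at all.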